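Amide nitrogen aryl swap in an E-selectin series

The source may report more compounds than this note shows. Statements on the series, on what has been measured and on what is new or still open speak of the compounds shown alone.

Measured compounds:
compound 1 `CCCCCCCCCCOc1cccc(OCCCCCC(=O)N(Cc2ccc(C(=O)OC)cc2)c2ccc(C(=O)OC)cc2)c1` — in an assay on isolated protein for binding affinity to E-selectin (Homo sapiens), read by ELISA, tested at 100 uM (on this read-out higher numbers stand for more inhibition at the one concentration tested (going by the name of the read-out) and lower numbers for less inhibition), compound 1 gives 65%
compound 2 `CCCCCCCCCCOc1cc(OCCCCCCCCCC)cc(OCCCCCC(=O)N(c2ccc(C(=O)O)cc2)c2cccc(C(=O)O)c2)c1` — in this assay compound 2 gives "not determined" (no result reported)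
compound 3 `CCCCCCCCCCOc1cc(OCCCCCCCCCC)cc(OCCCCCC(=O)N(Cc2ccc(C(=O)O)cc2)c2cccc(C(=O)O)c2)c1` — this assay: compound 3 gives 43%

Compound 1 holds the higher of the two numbers shown; compound 3 lies lower by a gap beyond the usual scatter, while compound 2 carries no number at all. Compound 3 differs from compound 1 in several places at once, so its lower value cannot be tied to any single change; the two values only show that the diacid with three decyloxy chains inhibits less at the tested concentration.

Compound 4 `CCCCCCCCCCOc1cccc(OCCCCCC(=O)N(Cc2ccc(C(=O)OC)cc2)c2cccc(C(=O)OC)c2)c1` is not yet measured. It carries the same atoms as compound 1, joined differently: 3-(methoxycarbonyl)phenyl in place of 4-(methoxycarbonyl)phenyl on an amide-type nitrogen. Within the data shown here, no single-change step is known, so the size of the step has to be guessed. The step is expected to be small and downward, a number 8 percentage points lower from compound 1 to compound 4 (within the scatter), within the scatter of repeated measurements. Compound 4 is estimated at 57%, with a range from 38% to 75%, resting on compound 1 with 65% as the only close reference.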

Compound 4, a percentage reported as inhibition, at one concentration (the size of the read-out at that concentration, not a potency): 18%
Compound 4: middle estimate off by 39 percentage points, on the high side, and the stated range ends above it.
By their numbers in this assay, from the lowest: compound 4; then compound 3; then compound 1.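

In this assay, among these compounds, the exchange of 4-(methoxycarbonyl)phenyl for 3-(methoxycarbonyl)phenyl on the amide-type nitrogen gives a number 47 percentage points lower from compound 1 to compound 4 (beyond the scatter) and is the first single-change step. The two groups have the same atoms and the same counts of donors, acceptors and double bonds, so the read-out at this position depends on where the methoxycarbonyl group sits on the phenyl ring and not only on which atoms are present. This position is therefore sensitive to an isomeric change alone, something the multi-place difference between compound 1 and compound 3 could not show, and no measured evidence bears on the reason for the step.

The compounds shown leave open whether a nitrile or a primary carboxamide in place of the methoxycarbonyl group would keep the inhibition seen with 4-(methoxycarbonyl)phenyl. As far as these compounds go, it also remains open whether a step of this size would appear on the core of compound 3, where the ring carries a carboxylic acid and the chain count differs.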